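Cyclopropyl for trifluoromethyl on a fused imidazole core

The compounds below may be only part of what the source reports. "The series", "measured", "known", "first", "only" and "open" are said of these compounds alone.

Measured compounds:
compound 1, `CCc1nc(C(F)(F)F)c2n1CCN([C@@H](C(=O)NC)c1ccccc1)[C@H]2CCc1ccc(C(F)(F)F)cc1`, 11 nM
compound 2, `CNC(=O)[C@@H](c1ccccc1)N1CCn2c(COC)nc(Cl)c2[C@@H]1CCc1ccc(C(F)(F)F)cc1`, 25 nM
compound 3, `CCOc1nc(CC)n2c1C(CCc1ccc(C(F)(F)F)cc1)N([C@@H](C(=O)NC)c1ccccc1)CC2`, 2750 nM

In a functional assay on CHO cells for antagonist activity at Orexin receptor type 2 (Homo sapiens), read by FLIPR and calcium flux (a higher number here means a weaker inhibitor, a lower number a stronger inhibitor), compound 1 gives the lowest of the three numbers. Compound 2 stands nearest to it, and its value lies beyond the scatter of compound 1; compound 3 stands furthest, far beyond the scatter, so within this small set compound 1 is the strongest inhibitor. Neither compound 2 nor compound 3 differs from compound 1 in one place only, so their values show only where each stands, not a single-change step.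

The unmeasured compound 4, `CCc1nc(C2CC2)c2n1CCN([C@@H](C(=O)NC)c1ccccc1)[C@H]2CCc1ccc(C(F)(F)F)cc1`, differs from compound 1 in one place: cyclopropyl in place of trifluoromethyl on an aromatic carbon. Within the data shown here, no step between measured compounds matches this exchange, and no other number shows what this place tolerates apart from the three values given. The expected step from compound 1 to compound 4 in this assay is a 2.3-fold higher number from compound 1 to compound 4 (0.36 log units; beyond the scatter), a modest weakening that may well sit within the scatter. Compound 4 is therefore estimated at 25 nM, with a range from 8 nM to 80 nM.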

Compound 4, half-maximal inhibitory concentration: 29 nM
For compound 4 the middle estimate is 1.2-fold (0.06 log units) below the measured one, within the range that was stated.
By their numbers in this assay, from the lowest: compound 1; then compounds 2 and 4 (each within the scatter of the next); then compound 3.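

In this assay, among these compounds, cyclopropyl in place of trifluoromethyl on this aromatic carbon gives a 2.6-fold higher number from compound 1 to compound 4 (0.42 log units; beyond the scatter), the first single-change step at this place and a modest one. Trifluoromethyl is therefore not required for inhibition here: with a three-membered ring of carbon only on this carbon of the shared core, compound 4 still gives 29 nM. Nothing shown here accounts for the size of this step.

The compounds shown leave open how an amine, a nitrile or a longer chain would fare on this carbon, so these two groups mark only two points in what the place accepts. They also leave open whether the same exchange would give a similar step with something other than the ethyl group on the same five-membered ring.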